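This account rests on a few compounds, and the source may have more. Where it says the series, first, only, none or still open, it means among the compounds named here.

Values for the series in a functional assay on A549 cells (Homo sapiens) for antiproliferative activity, read by MTT assay, with a stated time of 24 h (on this read-out lower numbers stand for stronger inhibition and higher numbers for weaker inhibition), follow.

- Compound 1 `O=C(NNc1ccccc1Cl)c1ccccc1NS(=O)(=O)c1cnc(O)nc1O` gives 5480 nM
- Compound 2 `O=C(NNc1ccc(F)cc1)c1ccccc1NS(=O)(=O)c1cnc(O)nc1O` gives > 20000 nM (a limit of the assay, not a number)
- Compound 3 `O=C(NNC(=O)c1ccccc1NS(=O)(=O)c1cnc(O)nc1O)c1ccccc1Cl` gives 5290 nM

Compound 3 stands level with compound 1 on these numbers, with a 1.0-fold lower number from compound 1 to compound 3 (0.02 log units; within the scatter) as the step between them. Its other neighbour is the compound that reached the limit, and an at least 3.7-fold lower number from compound 2 to compound 3 (0.57 log units; beyond the scatter) is the step on that side.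

The next analogue is compound 4 `O=C(NNC(=O)c1ccccc1NS(=O)(=O)c1cnc(O)nc1O)c1ccc(F)cc1`, which carries 4-fluorophenyl in place of 2-chlorophenyl on a carbonyl carbon on a carbonyl carbon whose other neighbour is an amide-type nitrogen. Within the data shown here, the nearest precedent is the same exchange on an amine nitrogen, an at least 3.6-fold higher number from compound 1 to compound 2 (0.56 log units; beyond the scatter), the only measured pair with this swap. That step is open-ended, as compound 2 stands at the limit of > 20000 nM in this assay, at which 1 of the 3 values shown sits, in this series. The match between the two 2-chlorophenyl compounds, seen in a 1.0-fold lower number from compound 1 to compound 3 (0.02 log units; within the scatter), gives some ground for carrying the precedent over to the carbonyl carbon.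

A modest step towards weaker inhibition is therefore expected in this assay, and a result at the limit would not be surprising. The expected step is a 2.3-fold higher number from compound 3 to compound 4 (0.36 log units; beyond the scatter) on this estimate. Compound 4 is estimated at 12000 nM with an expected range of 5000 nM to 30000 nM in this assay.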

Compound 4, half-maximal inhibitory concentration: > 20000 nM
Compound 4: a limit, no number (the forecaster's own chance of this, stated with the estimate: 35%); middle value at least 1.6-fold (0.22 log units) from the limit.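

In this assay, the exchange of 2-chlorophenyl for 4-fluorophenyl on a carbonyl carbon whose other neighbour is an amide-type nitrogen now has a direct reading, an at least 3.7-fold higher number from compound 3 to compound 4 (0.57 log units; beyond the scatter), and it runs the same way as the exchange on an amine nitrogen, an at least 3.6-fold higher number from compound 1 to compound 2 (0.56 log units; beyond the scatter). The comparison with the other 2-chlorophenyl compound, an at least 3.6-fold higher number from compound 1 to compound 4 (0.56 log units; beyond the scatter), shows that the (4-fluorophenyl)carbonyl group also gives no measurable value, so across the compounds shown only the two 2-chlorophenyl compounds give numbers. The step between compound 2 and compound 4 cannot be read, since each value is a limit and not a number: the limit of > 20000 nM in this assay, at which 2 of the 4 values shown sit.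

As far as these compounds go, the size of the 4-fluorophenyl step therefore stays open at both places, and it is unknown whether the two places would differ once numbers were available. The halogen and its ring position change together in this exchange. Values for 4-chlorophenyl, 2-fluorophenyl and unsubstituted phenyl on the same carbonyl carbon would be needed to tell whether the chlorine or its position goes with the measurable values.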